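The source may hold more compounds than are shown below. What is called first, only, known or untested is meant among the compounds shown, and "the series" means these compounds.

In a functional assay on UACC-62 cells (Homo sapiens) for cytotoxicity, read by sulforhodamine B assay (on this read-out lower numbers stand for stronger inhibition of growth and higher numbers for weaker inhibition of growth), compound 1 (`CC1=CC[C@@H]([C@@](C)(O)CCCC(C)(C)NC(=S)NN)CC1`) gives 18500 nM as its reading, compound 2 (`CC1=CC[C@@H]([C@@](C)(O)CCCC(C)(C)NC(=S)N/N=C\c2ccc(O)cc2)CC1`) gives 8870 nM and compound 3 (`CC1=CC[C@@H]([C@@](C)(O)CCCC(C)(C)NC(=S)N/N=C\c2cccc([N+](=O)[O-])c2)CC1`) gives 7840 nM on the same scale. Compound 2 therefore lies level with compound 3 and under compound 1, as the steps of a 1.1-fold lower number from compound 2 to compound 3 (0.05 log units; within the scatter) and a 2.1-fold lower number from compound 1 to compound 2 (0.32 log units; beyond the scatter) show. The change to compound 4 (`CC1=CC[C@@H]([C@@](C)(O)CCCC(C)(C)NC(=S)N/N=C\c2ccc(Cl)cc2)CC1`), still unmeasured, is chloro in place of hydroxy on an aromatic carbon and amounts to chloro in place of hydroxy on an aromatic carbon, para to a large group. For the measured compounds named here, the closest precedent is the step of a 1.1-fold lower number from compound 2 to compound 3 (0.05 log units; within the scatter) in which 3-nitrophenyl replaces 4-hydroxyphenyl, while the step of a 2.1-fold lower number from compound 1 to compound 2 (0.32 log units; beyond the scatter) concerns a group that compound 4 keeps. So in this assay no step beyond the scatter is expected for this exchange. The estimate amounts to a 1.2-fold lower number from compound 2 to compound 4 (0.07 log units; within the scatter) as an expected step. For compound 4 the estimated value is 7500 nM with an expected range from 4000 nM to 13000 nM in this read-out.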

Compound 4, concentration for 50% growth inhibition: 7350 nM
Compound 4: the middle estimate sits 1.0-fold (0.01 log units) above what was measured; measured number inside the range.
By their numbers in this assay, from the lowest: compounds 4, 3 and 2 (each within the scatter of the next); then compound 1.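

In this assay, for the compounds shown here, chloro in place of hydroxy on the aromatic carbon para to a large group isolates this one position for the first time (a 1.2-fold lower number from compound 2 to compound 4 (0.08 log units; within the scatter)), and the reading stays within the scatter even though the hydrogen-bond donor and acceptor counted for hydroxy are gone. The 4-chlorophenyl and 3-nitrophenyl compounds also cannot be told apart (a 1.1-fold lower number from compound 3 to compound 4 (0.03 log units; within the scatter)), so in these compounds the three aromatic groups give equivalent readings. The chloro compound still keeps a step beyond the scatter from the unsubstituted thiosemicarbazide end of compound 1 (a 2.5-fold lower number from compound 1 to compound 4 (0.40 log units; beyond the scatter)), as the hydroxy compound did.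

Going by these compounds, whether an amine or a carboxylic acid at this position would also leave the reading unchanged remains open. Nothing available explains why the exchange of hydroxy for chloro changes so little.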